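Cytotoxicity of a fluorinated nucleoside: azide versus acetamide

This account rests on a few compounds, and the source may have more. Where it says the series, first, only, none or still open, it means among the compounds named here.

Measured so far:
- Compound 1 `CC(=O)O[C@@H]1[C@H](OC(C)=O)[C@@H](CN=[N+]=[N-])O[C@H]1n1cnc2c(N)nc(F)nc21`: 18000 nM
- Compound 2 `CC(=O)NC[C@H]1O[C@@H](n2cnc3c(N)nc(F)nc32)[C@H](OC(C)=O)[C@@H]1OC(C)=O`: 138000 nM
- Compound 3 `[N-]=[N+]=NC[C@H]1O[C@@H](n2cnc3c(N)nc(F)nc32)[C@H](O)[C@@H]1O`: 3100 nM

All three compounds were tested in an ADME assay on L6 cells (Rattus norvegicus) for inhibition, read by resazurin assay, with a stated time of 72 h; on this read-out higher numbers stand for weaker inhibition and lower numbers for stronger inhibition. Compound 1 and compound 2 share one core and differ in a single place, (acetamido in place of azido on a saturated chain carbon bound to a saturated ring carbon). That change made a step of a 7.7-fold higher number from compound 1 to compound 2 (0.88 log units; beyond the scatter), so the acetamido compound inhibits the cells less strongly than the azido compound.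

Compound 3 carries the same azido group but on a different core: it lacks the two acetyl groups of compound 1, and the difference between the two cores is not broken down here. In this assay compound 3 gives the lowest of the three numbers, well apart from compound 1 and further still from compound 2.

Compound 4 `CC(=O)NC[C@H]1O[C@@H](n2cnc3c(N)nc(F)nc32)[C@H](O)[C@@H]1O` has not yet been measured. It relates to compound 3 exactly as compound 2 relates to compound 1: the difference is acetamido in place of azido on a saturated chain carbon bound to a saturated ring carbon, and the place is the same word for word, so this is the same change made on the second core. Within the data shown here, only one measured example of this change exists, so the expectation rests on that single step of compound 1 to compound 2 and on the value of compound 3, 3100 nM. The step from compound 3 to compound 4 is expected to be about a 7.1-fold higher number from compound 3 to compound 4 (0.85 log units; beyond the scatter), in the same direction as before, since nothing in the data points the other way. Compound 4 is therefore estimated at 22000 nM, with a plausible range from 8000 nM to 65000 nM.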

Compound 4, half-maximal inhibitory concentration: 182000 nM
For compound 4 the middle estimate is 8.3-fold (0.92 log units) below the measured one; measured number above the stated range.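

In this assay, putting acetamido in place of azido on the core of compound 3 again weakens inhibition of the cells, and the new step is a large one, with a 59-fold higher number from compound 3 to compound 4 (1.77 log units; beyond the scatter) on the core that lacks the two acetyl groups. Among these compounds, this shows that the direction of the change carried over from one core to the other, but it does not show that the size can be carried over, and with only two examples it cannot say why the size shifts or how it would behave on a third core. The direction held on both cores, yet the two steps are clearly not the same size, so a step measured on one core gives the sign of the change on the other but not a reliable number: the same change on two cores in this assay, a 7.7-fold higher number (0.88 log units; beyond the scatter) from compound 1 to compound 2 and a 59-fold higher number (1.77 log units; beyond the scatter) from compound 3 to compound 4, 7.7-fold (0.88 log units) apart, beyond the scatter of two such steps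

The compounds shown leave open whether azido stands out or acetamido falls behind, since only these two groups are compared at this place on the saturated chain carbon. An amine, a carboxylic acid or a longer chain in the same place could tell these readings apart, and could show whether the larger step on the core of compound 3 recurs with other groups.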